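This account rests on a few compounds, and the source may have more. Where it says the series, first, only, none or still open, it means among the compounds named here.

Working notes on the series. In an assay on isolated protein for inhibition of Myeloperoxidase (Homo sapiens), read by ELISA, with a stated time of 5 min (on this read-out lower numbers stand for stronger inhibition and higher numbers for weaker inhibition), compound 1 `NCCCc1c[nH]c2c(F)cccc12` gives 26 nM. Compound 3 `NCCCCc1c[nH]c2ccc(C(=O)O)cc12` is reported in this assay as "not active" (no number reported), without a number. Compound 2 `CCCc1c[nH]c2ccc(F)cc12` returns only a limit in this assay, > 100 nM, which is not a measured number. Compound 2 therefore sits at the limit of > 100 nM in this assay, at which 1 of the 3 values shown sits, and with compound 3 carrying no number either, compound 1 is the only entry that has a single measured value. Going by the values given here, no step between measured compounds differing in one place is available, so no measured change anchors the next comparison.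

Compound 4 `CNC(=O)CCCc1c[nH]c2ccc(F)cc12` is not yet measured in this assay. It differs from compound 2 by methylcarbamoyl in place of hydrogen on a saturated chain carbon, three bonds along the chain from an aromatic carbon. With compound 2 standing at a limit, the step from compound 2 to compound 4 is expected to be small in this assay, around a step that the limit leaves unreadable from compound 2 to compound 4, not clearly beyond the scatter in either direction. Compound 4 is estimated at 150 nM in this assay, with a range from 40 nM to 600 nM, and a fair chance that only a limit is returned again.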

Compound 4, half-maximal inhibitory concentration: 95 nM
For compound 4 the middle estimate is 1.6-fold (0.20 log units) above the measured one; the measured number falls inside the stated range.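

Methylcarbamoyl on a saturated chain carbon, three bonds along the chain from an aromatic carbon, gives a measured value in this assay, whereas the earlier single number came only from compound 1, which ends its chain in an amine. The change therefore leaves measurable inhibition on a chain with no terminal amine, and the step reads an at least 1.0-fold lower number from compound 2 to compound 4 (0.02 log units; that floor lies within the scatter). How much lies behind that floor cannot be read, since the starting point of the step is not a number: the limit of > 100 nM in this assay, at which 1 of the 4 values shown sits.

The compounds shown leave open whether the methyl on the amide nitrogen matters, as an unsubstituted carbamoyl or a dimethylcarbamoyl at the same place would show. They also leave open whether a hydroxyl at that place would serve as well as the methylcarbamoyl.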